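This account rests on a few compounds, and the source may have more. Where it says the series, first, only, none or still open, it means among the compounds named here.

The measured compounds and their values:

compound 1, `COc1cc(/C=C/C(=O)c2sc(Nc3cccc(Cl)c3)nc2C)cc(OC)c1OC`: > 25000 nM
compound 2, `COc1cc(/C=C/C(=O)c2sc(Nc3ccc(C)cc3)nc2C)cc(OC)c1OC`: > 25000 nM
compound 3, `COc1cccc(/C=C/C(=O)c2sc(Nc3cccc(Cl)c3)nc2C)c1`: > 25000 nM

In a functional assay on NCI-H460 cells (Homo sapiens) for cytotoxicity, read by MTT assay (on this read-out lower numbers stand for stronger inhibition and higher numbers for weaker inhibition), compound 1 gives > 25000 nM, which is a limit of the assay and not a number. Compound 2 gives > 25000 nM in this assay, again a limit. The step that the two limits leave unreadable from compound 1 to compound 2 is therefore not readable; the change it represents is 4-methylphenyl in place of 3-chlorophenyl on a nitrogen on an aromatic ring. Compound 3 gives > 25000 nM in this assay, likewise a limit. How the core of compound 3 differs from that of compound 1 is not broken down here. Compound 4, `COc1cccc(/C=C/C(=O)c2sc(Nc3ccc(C)cc3)nc2C)c1`, has not been measured; it differs from compound 3 by 4-methylphenyl in place of 3-chlorophenyl on a nitrogen on an aromatic ring, and the place of the change is the same, word for word, as in the change from compound 1 to compound 2, so it is the same change. All three values sit at the limit of > 25000 nM in this assay, at which 3 of the 3 values shown sit, so nothing measured shows this change moving the read-out. The step expected here, a step that the limit leaves unreadable from compound 3 to compound 4, rests on that unreadable step that the two limits leave unreadable from compound 1 to compound 2 and on (the limit of > 25000 nM in this assay, at which 3 of the 3 values shown sit). Compound 4 is therefore estimated at 40000 nM, between 15000 nM and 120000 nM, most likely reported as a limit.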

Compound 4, half-maximal inhibitory concentration: > 25000 nM
Compound 4: a limit, no number; the forecaster's own chance of this, stated with the estimate: 85%; the middle value is on the limit's open side.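

In this assay compound 4 gives > 25000 nM, which is a limit and not a number. Within the data shown here, no new step can therefore be read between compound 3 and compound 4, since both sit at the same limit: the limit of > 25000 nM in this assay, at which 4 of the 4 values shown sit. The compounds shown leave open whether 4-methylphenyl in place of 3-chlorophenyl moves the read-out in this assay.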